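The source may hold more compounds than are shown below. What is called first, only, known or untested is meant among the compounds shown, and "the series" means these compounds.

Compound 1 `NC(N)=NC(=O)c1nc(Cl)c(NC2CCCCC2)nc1N`: 92% in an assay for inhibition of acid-sensing ion channel 3 (Homo sapiens), read by patch clamp, tested at 20 uM; on this read-out higher numbers stand for more inhibition at the one concentration tested (going by the name of the read-out) and lower numbers for less inhibition. Compound 2 `CCCN(C)c1nc(N)c(C(=O)N=C(N)N)nc1Cl`: 91%.

Compound 2 stands lowest of the two in this assay, yet its nearest neighbour, compound 1, lies within the usual scatter of it. Compound 3 `CN(c1nc(N)c(C(=O)N=C(N)N)nc1Cl)C1CCCCC1` is not yet measured; it differs from compound 2 by cyclohexyl in place of propyl on a nitrogen on an aromatic ring. For the measured compounds named here, the one measured step that bears on this is a number 1 percentage points lower from compound 1 to compound 2 (within the scatter), where methyl(propyl)amino replaced cyclohexylamino with almost no effect. Because compound 1 already carried a cyclohexyl group and gave 92%, a step of no change at the digits printed from compound 2 to compound 3 (within the scatter) is expected, nothing beyond the scatter. Compound 3 is estimated at 91%, within 80% to 98%.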

Compound 3, a percentage reported as inhibition, at one concentration (the size of the read-out at that concentration, not a potency): 57%
The estimate for compound 3 lay 34 percentage points above the measured number; measured number outside the range, below it.
By their numbers in this assay, from the lowest: compound 3; then compounds 2 and 1 (each within the scatter of the next).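

On this nitrogen the two groups cannot be judged separately. Cyclohexyl in place of propyl gives a number 34 percentage points lower from compound 2 to compound 3 (beyond the scatter) in this measurement (this assay), and methyl in place of hydrogen gives a number 35 percentage points lower from compound 1 to compound 3 (beyond the scatter) even though methyl is present in compound 2, whose number stays high. Cyclohexyl and methyl each occur in a high-scoring compound, and only compound 3 carries both on that nitrogen; nothing measured here accounts for the drop. Still open, from the compounds shown here alone, is whether a cyclopentyl or a butyl chain paired with methyl keeps the number high, and whether ethyl paired with cyclohexyl does.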